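The source may report more compounds than this note shows. Statements on the series, on what has been measured and on what is new or still open speak of the compounds shown alone.

Three compounds have been measured in a functional assay on A549 cells (Homo sapiens) for antiproliferative activity, read by MTT assay, with a stated time of 72 h; a lower number here means a stronger inhibitor, a higher number a weaker inhibitor:

Compound 1 `CCCNC(=O)c1cc(Oc2ccc(NC(=O)c3nn(-c4ccc(C)cc4)c(=O)cc3C)cc2F)ccn1`: 18000 nM
Compound 2 `CCCNC(=O)c1cc(Oc2ccc(NC(=O)c3nn(-c4ccc(Br)cc4F)c(=O)cc3C)cc2F)ccn1`: 235000 nM
Compound 3 `CNC(=O)c1cc(Oc2ccc(NC(=O)c3nn(-c4cccc(C(F)(F)F)c4)c(=O)cc3C)cc2F)ccn1`: 10200 nM

Among these, compound 3 gives the lowest number of the three. The gap between compound 3 and compound 1 lies within the usual scatter, so the two cannot be told apart; the gap between compound 3 and compound 2 is well beyond the scatter. Among the measured compounds shown here, the only pair that differs in a single place is compound 1 and compound 2, and that step is large: a 13-fold higher number from compound 1 to compound 2 (1.12 log units; beyond the scatter). It concerns the group on the aromatic nitrogen and nothing else.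

Compound 4 `CCCNC(=O)c1cc(Oc2ccc(NC(=O)c3nn(-c4cccc(C(F)(F)F)c4)c(=O)cc3C)cc2F)ccn1` differs from compound 3 by ethyl in place of hydrogen on a saturated chain carbon bound to an amide-type nitrogen. For the measured compounds named here, no measured pair isolates this change. Compounds 1 and 2 carry a propylcarbamoyl group while compound 3 carries a methylcarbamoyl group, but those compounds also differ in the group on the aromatic nitrogen, so no clean comparison exists. Going by the values given here, with no direct precedent, the expectation is a step in this assay of no size beyond the scatter, in either direction: a 1.2-fold higher number from compound 3 to compound 4 (0.07 log units; within the scatter) is what the estimate means.

For compound 4 in this assay the expected value is 12000 nM, with a likely range from 4000 nM to 36000 nM.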

Compound 4, half-maximal inhibitory concentration: 9240 nM
The estimate for compound 4 lay 1.3-fold (0.11 log units) above the measured number; measured number inside the range.
By their numbers in this assay, from the lowest: compounds 4, 3 and 1 (each within the scatter of the next); then compound 2.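

Among the compounds shown here, changing methylcarbamoyl to propylcarbamoyl, with 3-(trifluoromethyl)phenyl kept on the aromatic nitrogen, gives a 1.1-fold lower number from compound 3 to compound 4 (0.04 log units; within the scatter) in this assay and is the first clean reading of this position: the added ethyl brings no change that can be told from the scatter. With propylcarbamoyl held fixed, the group on the aromatic nitrogen now gives two different answers: 3-(trifluoromethyl)phenyl in place of 4-bromo-2-fluorophenyl gives a 25-fold lower number from compound 2 to compound 4 (1.41 log units; beyond the scatter) and is a large step, whereas the same group in place of 4-methylphenyl gives a 1.9-fold lower number from compound 1 to compound 4 (0.29 log units; within the scatter) and leaves those two compounds indistinguishable. No measurement shown here offers an explanation for either result.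

From the compounds shown here alone, the chain result rests on a single pair, so it remains open whether methyl and propyl would also match with 4-methylphenyl or 4-bromo-2-fluorophenyl on the aromatic nitrogen. Also open, going by these compounds, is whether the position would stay as unresponsive with a longer chain such as hexyl, or with a chain ending in an amine or a carboxylic acid.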